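Trimethoxyphenyl in place of hydroxyphenyl on the acylhydrazone arm

A few compounds are considered here, and "the series" means these few. Any claim that something is new, unique, unknown or untested is made for them only; others in the source may bear on it.

Compound 1 `CN(C)CCn1cnnc1-c1cc(Oc2ccc(NC(=O)N/N=C/c3cccc(O)c3)cc2F)ccn1` gives 1370 nM in a functional assay on MKN-45 cells (Homo sapiens) for cytotoxicity, read by MTT assay, with a stated time of 72 h (on this read-out lower numbers stand for stronger inhibition and higher numbers for weaker inhibition), the higher of the two numbers measured here. For the measured compounds named here, compound 2 `CN(C)CCn1cnnc1-c1cc(Oc2ccc(NC(=O)N/N=C/c3ccc(Cl)cc3)cc2F)ccn1` gives 570 nM in this assay, and the one step measured so far, a 2.4-fold lower number from compound 1 to compound 2 (0.38 log units; beyond the scatter), follows the swap to 4-chlorophenyl in place of 3-hydroxyphenyl on a carbon with a double bond to nitrogen. Compound 3 `COc1cc(/C=N/NC(=O)Nc2ccc(Oc3ccnc(-c4nncn4CCN(C)C)c3)c(F)c2)cc(OC)c1OC` has not been measured; it differs from compound 1 by 3,4,5-trimethoxyphenyl in place of 3-hydroxyphenyl on a carbon with a double bond to nitrogen. Going by the values given here, the step from compound 1 to compound 2 is the only guide, and it replaced the same 3-hydroxyphenyl, giving a modest improvement. Going by these compounds, a change in the same direction is therefore expected from compound 1 to compound 3, estimated as a 1.5-fold lower number from compound 1 to compound 3 (0.18 log units; within the scatter), with wide uncertainty because the entering group is untested. Compound 3 is expected to give 900 nM in this assay, within a range of 300 nM to 3000 nM.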

Compound 3, half-maximal inhibitory concentration: 2900 nM
The estimate for compound 3 lay 3.2-fold (0.51 log units) below the measured number, within the range that was stated.
By their numbers in this assay, from the lowest: compound 2; then compound 1; then compound 3.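

In this assay, replacing 3-hydroxyphenyl on a carbon with a double bond to nitrogen does not always lower the number: 3,4,5-trimethoxyphenyl gives a 2.1-fold higher number from compound 1 to compound 3 (0.33 log units; beyond the scatter), the opposite direction to the step seen with 4-chlorophenyl. The comparison between the two entering groups shows a 5.1-fold higher number from compound 2 to compound 3 (0.71 log units; beyond the scatter), so this place separates the three aryl groups by more than the scatter, and the choice of group decides the direction of the change. Nothing on hand accounts for the rise with the trimethoxyphenyl group.

The compounds shown leave open whether a single methoxy group on the phenyl ring would move the number as the three together do. They also leave open how a phenyl ring carrying an amine or a carboxylic acid would read at this place.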